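The source may report more compounds than this note shows. Statements on the series, on what has been measured and on what is new or still open speak of the compounds shown alone.

Working notes on the series

All members share one core; the variable part sits on a nitrogen on an aromatic ring whose other neighbour is an aromatic carbon. Compound 1 `CCCCCCCCCCCCNc1nc(SCc2ccc(C(F)(F)F)cc2)nc2ccccc12` carries a long saturated chain there. In a functional assay on MDA-MB-231 cells (Homo sapiens) for cytotoxicity, read by MTT assay, with a stated time of 72 h (a lower number here means a stronger inhibitor, a higher number a weaker inhibitor), compound 1 gives > 50000 nM, which is a limit of the assay and not a number. Compound 2 `COc1ccccc1Nc1nc(SCc2ccc(C(F)(F)F)cc2)nc2ccccc12` carries 2-methoxyphenyl at that nitrogen. In this assay compound 2 gives > 50000 nM, again a limit. Compound 3 `CCOc1ccccc1Nc1nc(SCc2ccc(C(F)(F)F)cc2)nc2ccccc12` differs from compound 2 by methyl in place of hydrogen on a saturated chain carbon bound to an oxygen on an aromatic ring. In this assay compound 3 gives > 50000 nM, also a limit.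

Among the compounds with values here, compound 2 therefore stands at the limit of > 50000 nM in this assay, at which 3 of the 3 values shown sit, and nothing among the measured values separates it from compound 1 or compound 3. Within the data shown here, the only measured step, a step that the two limits leave unreadable from compound 2 to compound 3, cannot be read in size because both ends are limits.

Compound 4 `O=[N+]([O-])c1ccc(Nc2nc(SCc3ccc(C(F)(F)F)cc3)nc3ccccc23)cc1` differs from compound 2 by 4-nitrophenyl in place of 2-methoxyphenyl on a nitrogen on an aromatic ring. Among the measured compounds shown here, no measured step touches this exchange, so there is no measured basis for a shift in either direction. The step from compound 2 to compound 4 in this assay is expected to be a number no higher from compound 2 to compound 4 (the limit leaves the size open), most likely ending at the limit once more. Compound 4 is estimated at 50000 nM, in a range from 10000 nM to 200000 nM.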

Compound 4, half-maximal inhibitory concentration: 8670 nM
The estimate for compound 4 lay 5.8-fold (0.76 log units) above the measured number; measured number outside the range, below it.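

In this assay, the exchange of 2-methoxyphenyl for 4-nitrophenyl on a nitrogen on an aromatic ring gives an at least 5.7-fold lower number from compound 2 to compound 4 (0.76 log units; beyond the scatter), which shows that the read-out at this position can move off the limit of the assay. The exchange of 2-ethoxyphenyl for 4-nitrophenyl at the same nitrogen gives an at least 5.7-fold lower number from compound 3 to compound 4 (0.76 log units; beyond the scatter), so compound 4 is separated beyond the scatter from both of these compounds, and the step from compound 2 to compound 3 remains unreadable. Both readable steps give only a minimum size, and the value of compound 2 remains a limit and not a number: the limit of > 50000 nM in this assay, at which 3 of the 4 values shown sit.

The exchange removes the alkoxy group and introduces the nitro group in a single change, so the compounds shown leave open which of the two goes with the lower number. On these data alone, how an amine or a carboxylic acid on the phenyl ring at that nitrogen would read in this assay also stays open, as does whether any such group would give a lower number than compound 4.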